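A few compounds are considered here, and "the series" means these few. Any claim that something is new, unique, unknown or untested is made for them only; others in the source may bear on it.

Working notes on the hydrazone series. Among the measured compounds shown here, compound 1 `COc1c(N2CCN(C)CC2)c(F)cc2c(=O)c(C(=O)N/N=C\c3c(Cl)cccc3Cl)cn(C3CC3)c12` has the lowest of the two numbers so far in a functional assay on PC-3 cells (Homo sapiens) for inhibition, read by MTT assay (a higher number here means a weaker inhibitor, a lower number a stronger inhibitor), giving 4.9 ug/mL. Compound 2 `COc1c(N2CCN(C)CC2)c(F)cc2c(=O)c(C(=O)N/N=C\c3ccc(O)cc3)cn(C3CC3)c12` gives 14.4 ug/mL, a step of a 2.9-fold higher number from compound 1 to compound 2 (0.47 log units; beyond the scatter). The next compound, compound 3 `COc1c(N2CCN(C)CC2)c(F)cc2c(=O)c(C(=O)N/N=C\c3cccc(C)c3)cn(C3CC3)c12`, carries the change (3-methylphenyl in place of 2,6-dichlorophenyl on a carbon with a double bond to nitrogen). For the measured compounds named here, only the step from compound 1 to compound 2 bears on this, and it was modest; a step of similar size or smaller in the same direction is expected here, a 1.6-fold higher number from compound 1 to compound 3 (0.21 log units; within the scatter). Compound 3 is estimated at 8 ug/mL, within 4 ug/mL to 16 ug/mL.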

Compound 3, half-maximal inhibitory concentration: 10 ug/mL
Compound 3: middle estimate off by 1.3-fold (0.10 log units), on the low side, within the range that was stated.
By their numbers in this assay, from the lowest: compound 1; then compounds 3 and 2 (each within the scatter of the next).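

In this assay, 3-methylphenyl in place of 2,6-dichlorophenyl on the carbon with a double bond to nitrogen gives a 2.0-fold higher number from compound 1 to compound 3 (0.31 log units; beyond the scatter), so a second replacement lacking chlorine also separates from compound 1. The two replacements cannot be told apart, with a 1.4-fold lower number from compound 2 to compound 3 (0.16 log units; within the scatter) between them. Nothing at hand explains either step.

Open, going by these compounds, is how 2-chlorophenyl, with a single chlorine, would compare with compound 1 in this assay. Also open, on these data alone, is how a phenyl ring carrying an amine or a carboxylic acid would read at this position.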